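This account rests on a few compounds, and the source may have more. Where it says the series, first, only, none or still open, it means among the compounds named here.

The shared core of compound 1 `CCN(CC)c1ncnc2c1ncn2CC1CC1` carries a diethylamino group on an aromatic carbon, and in a functional assay on the whole organism for inhibition, with Rattus norvegicus as the target, at a dose of 25 mg/kg by the intraperitoneal route (on this read-out higher numbers stand for more inhibition at the one dose given (going by the name of the read-out) and lower numbers for less inhibition), compound 1 gives 0%. Within the data shown here, compound 2 `c1nc(N2CCCCC2)c2ncn(CC3CC3)c2n1` carries piperidin-1-yl at the same place, and in this assay compound 2 gives 28%, which is the highest of the two numbers measured so far; the step of a number 28 percentage points higher from compound 1 to compound 2 (beyond the scatter) is the only measured step and stands beyond the scatter.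

Compound 3 `CC(C)(C)Nc1ncnc2c1ncn2CC1CC1` is the next compound, not yet measured. It differs from compound 2 in one place: (tert-butyl)amino in place of piperidin-1-yl on an aromatic carbon. Among the measured compounds shown here, no measured step shows what removing the ring of piperidin-1-yl or bringing in the hydrogen-bond donor of (tert-butyl)amino does here; the step of a number 28 percentage points higher from compound 1 to compound 2 (beyond the scatter) shows only that exchanging one ring-free amino group for a ring-bearing one raised inhibition, and compound 3 moves back toward a ring-free group. The expectation for this assay is therefore a modest drop, a number 16 percentage points lower from compound 2 to compound 3 (beyond the scatter), and compound 3 is estimated to give 12%, with a range from 0% to 40%.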

Compound 3, a percentage reported as inhibition, in the whole organism at one dose (the size of the read-out at that dose, not a potency): 0%
Estimate against measurement, compound 3: 12 percentage points above, and the stated range covers the measured number.
By their numbers in this assay, from the lowest: compounds 1 and 3 (each within the scatter of the next); then compound 2.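

Exchanging piperidin-1-yl for (tert-butyl)amino on the aromatic carbon gives a number 28 percentage points lower from compound 2 to compound 3 (beyond the scatter) in this assay, so the inhibition gained with piperidin-1-yl is not kept with this ring-free group. Set against the diethylamino group, the same exchange gives no change at the digits printed from compound 1 to compound 3 (within the scatter), which means that two different ring-free amino groups at this place read alike, and among the three groups only piperidin-1-yl stands apart from the others. Nothing available gives a reason for this difference between the groups.

The three compounds leave open whether any ring on this nitrogen would give the same result or whether the result belongs to piperidin-1-yl alone, a question that pyrrolidin-1-yl, morpholin-4-yl or a cyclohexylamino group at the same aromatic carbon would address. They also leave open whether compound 1 and compound 3 would still read alike at other doses, and whether the hydrogen-bond donor of (tert-butyl)amino has any bearing on the result, since the single dose used here gives no way of ranking these two compounds.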